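The source may hold more compounds than are shown below. What is called first, only, known or untested is meant among the compounds shown, and "the series" means these compounds.

Compound 1, with the structure `Oc1ccccc1/C=N/c1nnc(SCc2nnc(-c3ccccc3)o2)s1`, carries an unsubstituted phenyl group on its five-membered ring; in a functional assay on MCF7 cells (Homo sapiens) for inhibition, read by CCK-8 assay (on this read-out lower numbers stand for stronger inhibition and higher numbers for weaker inhibition), compound 1 gives 9760 nM. Compound 2, with the structure `Oc1ccccc1/C=N/c1nnc(SCc2nnc(-c3ccc(Cl)cc3)o2)s1`, differs from it only by a chlorine on that phenyl ring, and in this assay compound 2 gives 7550 nM. Among the compounds with values here, the one step measured so far, a 1.3-fold lower number from compound 1 to compound 2 (0.11 log units; within the scatter), stays within the scatter, so compound 1 and compound 2 cannot be told apart on these numbers. Among the two measured values, compound 2 holds the smaller number, but the gap to compound 1 does not count as a difference.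

Compound 3, with the structure `Oc1ccccc1/C=N/c1nnc(SCc2nnc(-c3ccccc3Br)o2)s1`, is the next member: 2-bromophenyl in place of 4-chlorophenyl on an aromatic carbon. Within the data shown here, no measured step matches this change directly; the only step available, from hydrogen to chlorine on the same phenyl ring, was too small to register. On that basis the expectation for compound 3 is a step of a 1.1-fold higher number from compound 2 to compound 3 (0.03 log units; within the scatter), that is, nothing beyond the scatter. Compound 3 is therefore estimated at 8000 nM in this assay, with a plausible range from 3500 nM to 18000 nM.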

Compound 3, half-maximal inhibitory concentration: 9140 nM
The estimate for compound 3 lay 1.1-fold (0.06 log units) below the measured number, within the range that was stated.
By their numbers in this assay, from the lowest: compounds 2, 3 and 1 (each within the scatter of the next).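

In this assay, replacing 4-chlorophenyl with 2-bromophenyl on this aromatic carbon of the five-membered ring changes both the halogen and its place on the phenyl ring, and the outcome is a 1.2-fold higher number from compound 2 to compound 3 (0.08 log units; within the scatter), so even this double change does not register. Measured against the unsubstituted phenyl group, the bromo compound shows a 1.1-fold lower number from compound 1 to compound 3 (0.03 log units; within the scatter), so a second halogen also fails to separate itself from hydrogen, and compounds 1, 2 and 3 cannot be told apart on these numbers. No other measurement is available to explain this flat result.

Since the halogen and its place changed together, these compounds cannot show what each contributes alone, and a direct comparison would need 4-bromophenyl or 2-chlorophenyl. On these data alone, it also remains open whether a quite different group at this position, such as an amine or a carboxylic acid on the phenyl ring, or a longer chain in place of that ring, would shift the number beyond the scatter.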